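Sulfonamide hydrazone series: working notes toward compound 4

A few compounds are considered here, and "the series" means these few. Any claim that something is new, unique, unknown or untested is made for them only; others in the source may bear on it.

Measured so far in a functional assay on HepG2 cells (Homo sapiens) for cytotoxicity, read by sulforhodamine B assay, with a stated time of 48 h; on this read-out lower numbers stand for stronger inhibition and higher numbers for weaker inhibition:
compound 1 `C/C(=N\NC(=O)/C(C#N)=C/N(C)C)c1ccc(NS(=O)(=O)c2ccc(Cl)cc2)cc1` gives 19400 nM
compound 2 `CSC(SC)=C(C#N)C(=O)N/N=C(\C)c1ccc(NS(=O)(=O)c2ccc(Cl)cc2)cc1` gives 19400 nM
compound 3 `CCOC(=O)c1c(-c2ccccc2)c(C#N)c(=O)n(/N=C(\C)c2ccc(NS(=O)(=O)c3ccc(Cl)cc3)cc2)c1N` gives 16800 nM

Compound 3 carries the lowest of the three numbers in this assay, but its gap to compound 1 and its gap to compound 2 both lie within the scatter, so no order among the three can be drawn from these values. Within the data shown here, the single step between measured compounds that differ in one place, no change at the digits printed from compound 1 to compound 2 (within the scatter), concerns the group on the carbonyl carbon of the hydrazide and is flat within the scatter; it does not touch the ring that is altered in the next compound.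

Compound 4 `CCOC(=O)c1c(/C=C/c2ccccc2)c(C#N)c(=O)n(/N=C(\C)c2ccc(NS(=O)(=O)c3ccc(Cl)cc3)cc2)c1N` differs from compound 3 by 2-phenylethenyl in place of phenyl on an aromatic carbon. Among the measured compounds shown here, no measured pair shows this change, and the only measured step bears on another part of the shared core. For the measured compounds named here, nothing among the measured compounds supports a step beyond the scatter in this assay in either direction. The expected step is a 1.1-fold lower number from compound 3 to compound 4 (0.02 log units; within the scatter), that is, no change beyond the scatter. The estimate for compound 4 in this assay is 16000 nM, with a range from 6000 nM to 45000 nM.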

Compound 4, half-maximal inhibitory concentration: 10700 nM
The estimate for compound 4 lay 1.5-fold (0.17 log units) above the measured number; low and high end bracket the measured number.
By their numbers in this assay, from the lowest: compounds 4, 3, 1 and 2 (each within the scatter of the next).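

At the aromatic carbon opposite the ring nitrogen, swapping phenyl (6 heavy atoms) for 2-phenylethenyl (8 heavy atoms, with a double bond outside aromatic rings) gives a 1.6-fold lower number from compound 3 to compound 4 (0.20 log units; within the scatter) in this assay, where compound 3 gives 16800 nM and compound 4 gives 10700 nM. Among these compounds, this is the first measured change at this position, since the earlier step concerned the group on the carbonyl carbon, and here too the printed step does not leave the scatter, so the larger carbon-only group does not separate compound 4 from compound 3 on this read-out. No measurement at hand bears on the reason for this outcome at this position.

The two groups compared at this position are both carbon-only and each holds one six-membered aromatic ring, so the compounds shown do not tell whether a group of another kind, such as an amine, a carboxylic acid or a simple alkyl chain, would move the number beyond the scatter. As far as these compounds go, whether 2-phenylethenyl behaves the same way with another group in place of the ethoxycarbonyl group also remains open.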